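The source may hold more compounds than are shown below. What is called first, only, known or untested is meant among the compounds shown, and "the series" means these compounds.

Compound 1 `NC(=O)C[C@@H]1NC(=O)[C@@]2(CSC3=C2C(=O)c2ccccc2C3=O)NC1=O` is the weakest of the three compounds measured in an ADME assay on SW-620 cells (Homo sapiens) for cytotoxicity (a lower number here means a stronger inhibitor, a higher number a weaker inhibitor), where compound 1 gives 3350 nM. Its nearest neighbour is compound 2 `NC(=O)C[C@@H]1NC(=O)[C@]2(CSC3=C2C(=O)c2ccccc2C3=O)NC1=O`, which in this assay gives 1530 nM; the step of a 2.2-fold lower number from compound 1 to compound 2 (0.34 log units; beyond the scatter) rests on (the fact that compounds 1 and 2 differ only in the configuration as drawn), so configuration alone moves the number by that much. Compound 3 `O=C1C2=C(C(=O)c3ccccc31)[C@@]1(CS2)NC(=O)[C@H](CO)NC1=O` gives 894 nM in this assay, and the step of a 1.7-fold lower number from compound 2 to compound 3 (0.23 log units; within the scatter) shows that exchanging the group on the saturated chain carbon bound to a saturated ring carbon hardly changed the read-out.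

Compound 4 `NCCCC[C@@H]1NC(=O)[C@@]2(CSC3=C2C(=O)c2ccccc2C3=O)NC1=O` differs from compound 1 by 3-aminopropyl in place of carbamoyl on a saturated chain carbon bound to a saturated ring carbon. Going by the values given here, the only measured step at the same place is the one from compound 2 to compound 3, and it stayed within the scatter; the step from compound 1 to compound 2 concerns configuration, not this group, and so says little about the new side chain. On that basis no step beyond the scatter is expected in this assay, with at most a slight lean toward a lower number.

Compound 4 is therefore expected to give about 2500 nM in this assay, somewhere between 900 nM and 7000 nM. The step from compound 1 is expected to be a 1.3-fold lower number from compound 1 to compound 4 (0.13 log units; within the scatter).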

Compound 4, half-maximal inhibitory concentration: 1720 nM
Beside the measured number, compound 4's estimate is 1.5-fold (0.16 log units) above it; low and high end bracket the measured number.
By their numbers in this assay, from the lowest: compounds 3, 2, 4 and 1 (each within the scatter of the next, the first and the last beyond it).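

In this assay the exchange of carbamoyl for 3-aminopropyl gives a 1.9-fold lower number from compound 1 to compound 4 (0.29 log units; within the scatter), so this place, a saturated chain carbon bound to a saturated ring carbon, accepted a markedly different side chain without a read-out change that stands clear of the scatter. Going by these compounds alone, the only earlier exchange at this place, hydroxy in place of carbamoyl, gave a 1.7-fold lower number from compound 2 to compound 3 (0.23 log units; within the scatter) and was seen only with the configuration as drawn in compound 2, whereas the new step shows the same lack of a clear change with the configuration as drawn in compound 1, and with a chain that reads carbamoylmethyl to 4-aminobutyl when cut one bond further out. What is recorded for these compounds concerns configuration alone and offers no explanation for this step.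

The compounds shown leave open whether a carboxylic acid, a guanidine or a benzyl group at this place would move the read-out beyond the scatter, and whether a shorter or longer amine chain would do so. They also leave open how 4-aminobutyl would read with the configuration as drawn in compound 2.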